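The compounds below may be only part of what the source reports. "The series", "measured", "known", "first", "only" and "open" are said of these compounds alone.

Of the compounds shown here, three built on one shared core have been tested in an assay on isolated protein for inhibition of 2-Hydroxyacid oxidase 2 (Homo sapiens), tested at 10 uM; a higher number here means a stronger effect of the compound at the concentration tested, a lower number a weaker effect. Compound 1 `Cc1n[nH]c(C(=O)O)c1Cc1cccc(-c2ccc(C#N)cc2)c1` gives 46%, the highest of the three numbers. Compound 3 `Cc1n[nH]c(C(=O)O)c1Cc1cccc(-c2ccc(OC(F)(F)F)cc2)c1` gives 34%, and compound 2 `Cc1n[nH]c(C(=O)O)c1Cc1cc2ccccc2s1` gives 29%. Among the measured compounds shown here, the only step between two compounds that differ in a single place is a number 12 percentage points lower from compound 1 to compound 3 (beyond the scatter), a modest fall that lies beyond the scatter. The gap from compound 1 down to compound 2 is wider and also lies beyond the scatter, though the two structures differ in more than one place.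

Compound 4 `Cc1n[nH]c(C(=O)O)c1Cc1cccc(C(N)=O)c1` has not yet been measured. Its difference from compound 1 is the following: carbamoyl in place of 4-cyanophenyl on an aromatic carbon. This removes a good part of what compound 1 carries on its core. For the measured compounds named here, no measured step matches such a change: the step from compound 1 to compound 3 only exchanged one group for another on the outer ring, and the outer ring itself stayed. The available numbers therefore give only an indirect guide. Taking away the whole outer ring is expected to cost more than exchanging a group on it, so a fall beyond the scatter is expected, estimated as a number 26 percentage points lower from compound 1 to compound 4 (beyond the scatter). Compound 4 is therefore expected to give about 20%, within a range from 5% to 40%.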

Compound 4, a percentage reported as inhibition, at one concentration (the size of the read-out at that concentration, not a potency): 8%
Estimate against measurement, compound 4: 12 percentage points above, within the range that was stated.
By their numbers in this assay, from the lowest: compound 4; then compounds 2 and 3 (each within the scatter of the next); then compound 1.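

In this assay, replacing 4-cyanophenyl with carbamoyl gives a number 38 percentage points lower from compound 1 to compound 4 (beyond the scatter), a large fall, whereas exchanging only the group on the outer ring gave a number 12 percentage points lower from compound 1 to compound 3 (beyond the scatter). So the number at this position depends far more on keeping or losing the whole outer ring than on the one exchange of a group on that ring seen so far, although this change does several things at once: it removes a six-membered aromatic ring and a triple bond, reduces the group from 8 heavy atoms to 3, and adds a hydrogen-bond donor, so the step cannot be assigned to any one of these. Nothing available explains why the number falls.

Still open, as far as these compounds go, is whether the fall comes from losing the outer ring or from the carbamoyl itself, and an unsubstituted phenyl or a methyl at the same place would help to separate the two. From the compounds shown here alone, it is also open how far the number can be raised with the outer ring kept, for instance with an amine or a carboxylic acid in place of the nitrile.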